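Iodo to thiophen-2-yl on a shared core, starting from a limit

This account rests on a few compounds, and the source may have more. Where it says the series, first, only, none or still open, it means among the compounds named here.

Three compounds on a shared core were examined in an ADME assay on HEL cells (Homo sapiens) for cytotoxicity, with a stated time of 3 days; on this read-out lower numbers stand for higher toxicity in this test and higher numbers for lower toxicity in this test. Compound 1 `Cc1cc(-c2ccsc2)cn2c(CSCCc3ccccc3)cnc12` carries a thiophen-3-yl group on the core. In this assay compound 1 sits at a limit of >= 4 ug/mL. Compound 2 `COc1ccc(-c2cc(C)c3ncc(CSCCc4ccccc4)n3c2)cc1` carries 4-methoxyphenyl in that place, and in this assay compound 2 gives 20 ug/mL. Compound 3 `Cc1cc(I)cn2c(CSCCc3ccccc3)cnc12` carries iodo there. In this assay compound 3 sits at a limit of >= 0.8 ug/mL, so its standing among the three is a boundary rather than a number. Of the measured steps that reach compound 3, a step that the two limits leave unreadable from compound 1 to compound 3 and a step that the limit leaves unreadable from compound 2 to compound 3; the boundaries the limit of >= 0.8 ug/mL in this assay, at which 1 of the 3 values shown sits, and the limit of >= 4 ug/mL in this assay, at which 1 of the 3 values shown sits, leave both without a size.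

Compound 4 `Cc1cc(-c2cccs2)cn2c(CSCCc3ccccc3)cnc12` has not yet been measured. Its change from compound 3 is thiophen-2-yl in place of iodo on an aromatic carbon. Within the data shown here, no measured step bears directly on an entering thiophen-2-yl group, and the two steps onto compound 3 are unreadable, so no size of step can be expected with confidence; the nearest point of comparison is compound 1, which carries the related thiophen-3-yl group and rests at a limit. Compound 4 is therefore expected near 10 ug/mL, with a range from 2 ug/mL to 40 ug/mL. The step this estimate means is expected to be a step that the limit leaves unreadable from compound 3 to compound 4, and it may itself end at a limit.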

Compound 4, minimum cytotoxic concentration: 20 ug/mL
Estimate against measurement, compound 4: 2.0-fold (0.30 log units) below, within the range that was stated.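

In this assay the series now holds its first readable step at this aromatic carbon, and it is no change at the digits printed from compound 2 to compound 4 (within the scatter). Thiophen-2-yl and 4-methoxyphenyl therefore cannot be told apart in this read-out, although they are different groups, and as this is a single pair, it sets no wider pattern for the position. The steps to compound 4 from compound 3 and from compound 1 cannot be read, so the change from iodo to thiophen-2-yl and the shift of the thiophene attachment both remain without a size.

As far as these compounds go, whether thiophen-2-yl differs from thiophen-3-yl or from iodo at this place stays open, as does how an amine or a carboxylic acid on this aromatic carbon would read in this assay. Compound 3 offers only a limit as its point of comparison: the limit of >= 0.8 ug/mL in this assay, at which 1 of the 4 values shown sits.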